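Series notes: phenyl in place of bromo on compound 3

The compounds below may be only part of what the source reports. "The series", "measured", "known", "first", "only" and "open" are said of these compounds alone.

Compound 3 `COc1ccc(/C=C/c2cc(OC)cc(OC)c2/C=C/C(=O)c2ccc(Br)cc2)cc1` gives 12.9 ug/mL in a functional assay on HepG2 cells (Homo sapiens) for antiproliferative activity, read by MTT assay, with a stated time of 48 h (on this read-out lower numbers stand for stronger inhibition and higher numbers for weaker inhibition), the second highest of the three numbers. Compound 1 `CCCCCCOc1ccc(C(=O)/C=C/c2c(/C=C/c3ccc(OC)cc3)cc(OC)cc2OC)cc1` gives 16.2 ug/mL, and the step of a 1.3-fold lower number from compound 1 to compound 3 (0.10 log units; within the scatter) lies within the scatter. Compound 2 `COc1ccc(/C=C/c2cc(OC)cc(OC)c2/C=C/C(=O)c2ccc(C)c(C)c2)cc1` gives 0.2 ug/mL, so the step of a 65-fold higher number from compound 2 to compound 3 (1.81 log units; beyond the scatter) is large. Compound 4 `COc1ccc(/C=C/c2cc(OC)cc(OC)c2/C=C/C(=O)c2ccc(-c3ccccc3)cc2)cc1` differs from compound 3 by phenyl in place of bromo on an aromatic carbon. Among the compounds with values here, two measured steps bear on this part of the molecule: hexyloxy to bromo changed little, whereas 3,4-dimethylphenyl to 4-bromophenyl on the carbonyl carbon changed a great deal; neither involves phenyl. The expected step of a 1.6-fold lower number from compound 3 to compound 4 (0.21 log units; within the scatter) is therefore uncertain and not clearly beyond the scatter in either direction. Compound 4 is estimated at 8 ug/mL, with a range from 1.5 ug/mL to 30 ug/mL.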

Compound 4, half-maximal inhibitory concentration: 10.5 ug/mL
Compound 4: middle estimate off by 1.3-fold (0.12 log units), on the low side, within the range that was stated.
By their numbers in this assay, from the lowest: compound 2; then compounds 4, 3 and 1 (each within the scatter of the next).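

Swapping bromo for phenyl, six heavy atoms in place of one, leaves the number where it was (a 1.2-fold lower number from compound 3 to compound 4 (0.09 log units; within the scatter)), and hexyloxy at this position reads the same (a 1.5-fold lower number from compound 1 to compound 4 (0.19 log units; within the scatter)). So three very different groups on this aromatic carbon give no separation, while 3,4-dimethylphenyl in place of 4-phenylphenyl stands apart as the one exception (a 53-fold higher number from compound 2 to compound 4 (1.72 log units; beyond the scatter)). Nothing measured here accounts for either result.

On these data alone, whether an amine or a carboxylic acid on this carbon would also leave the number unmoved stays open. So does whether one methyl alone, or both methyl groups of compound 2, accounts for its gap.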